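The compounds below may be only part of what the source reports. "The series", "measured", "known", "first", "only" and "open" are said of these compounds alone.

Within the data shown here, in a functional assay on NIH3T3 cells (Mus musculus) (a higher number here means that more compound is needed for the effect, a lower number that less compound is needed), compound 3 (`Cn1cncc1C(OCc1ccc(C#N)nc1-c1ccccc1)c1ccc(C#N)cc1`) reads 19 nM and so carries the highest number of the three compounds measured so far. On the same scale compound 2 (`Cn1cncc1C(OCc1ccc(C#N)nc1-c1ccc2ccccc2c1)c1ccc(C#N)cc1`) gives 7.4 nM and compound 1 (`Cn1cncc1C(OCc1ccc(C#N)nc1-c1ccc(OC(F)(F)F)cc1)c1ccc(C#N)cc1`) gives 4 nM on the shared core, and the gap between these two (a 1.9-fold higher number from compound 1 to compound 2 (0.27 log units; within the scatter)) lies within the scatter. Compound 4 (`Cn1cncc1C(OCc1ccc(C#N)nc1-c1cc(Cl)cc(Cl)c1)c1ccc(C#N)cc1`) has 3,5-dichlorophenyl in place of the phenyl of compound 3 on an aromatic carbon (3,5-dichlorophenyl in place of phenyl on an aromatic carbon) and is otherwise unchanged. Among the measured compounds shown here, two measured steps touch the same phenyl. Adding trifluoromethoxy to it marks one modest step (a 4.8-fold higher number from compound 1 to compound 3 (0.68 log units; beyond the scatter)) and naphthalen-2-yl in its place marks another (a 2.6-fold higher number from compound 2 to compound 3 (0.41 log units; beyond the scatter)), both beyond the scatter. In both, the plain phenyl holds the higher number, and neither measured step runs the other way. For the measured compounds named here, no measured compound carries chlorine, so the carry-over to compound 4 remains uncertain. On the strength of those two steps, a modest move to a lower number is expected in this assay of a size similar to theirs. The estimated change (a 2.9-fold lower number from compound 3 to compound 4 (0.47 log units; beyond the scatter)) would therefore lie beyond the scatter. Compound 4 is estimated at 6.5 nM with an expected range of 2.5 nM to 17 nM until it is measured.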

Compound 4, half-maximal effective concentration: 6 nM
For compound 4 the middle estimate is 1.1-fold (0.03 log units) above the measured one; the range from low to high includes it.
By their numbers in this assay, from the lowest: compounds 1, 4 and 2 (each within the scatter of the next); then compound 3.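

In this assay, the step to the 3,5-dichlorophenyl group (a 3.2-fold lower number from compound 3 to compound 4 (0.50 log units; beyond the scatter)) gives a third replacement for the plain phenyl at this place, next to the ring nitrogen, that holds a lower number, and the first that carries chlorine. Among the four compounds shown, all three replacements lie below the phenyl of compound 3, and none goes against this, so the drop at this position is not tied to trifluoromethoxy or to the naphthalen-2-yl group. The three replacements also cannot be told apart here: both a 1.2-fold lower number from compound 2 to compound 4 (0.09 log units; within the scatter) and a 1.5-fold higher number from compound 1 to compound 4 (0.18 log units; within the scatter) stay within the scatter, even though the groups differ in shape and atoms. Nothing shown here bears on what lies behind this shift.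

Going by these compounds, it remains open whether a single chlorine on the phenyl would give the same drop, or whether the two chlorines are each needed. Also open, on these data alone, is how a carboxylic acid or an aminomethyl group on this phenyl would read, and whether a saturated ring such as cyclohexyl could stand in its place.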